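The source may hold more compounds than are shown below. What is called first, only, known or untested is meant among the compounds shown, and "the series" means these compounds.

Measured in an ADME assay on J774 cells (Mus musculus) for cytotoxicity; on this read-out lower numbers stand for an effect already at smaller amounts and higher numbers for an effect only at larger amounts of compound:

Compound 1 (`CCCCc1cc2c(=O)c(C(=O)OCC)c[nH]c2cc1OCCOc1ccccc1`): > 20000 nM (a limit)
Compound 2 (`CCCCc1cc2c(=O)c(C(=O)O)c[nH]c2cc1OCCOc1ccccc1`): > 20000 nM (a limit)
Compound 3 (`CCCCc1cc2c(=O)c(C(=O)NC(C)C)c[nH]c2cc1OCCOc1ccccc1`): > 20000 nM (a limit)

Compound 3 therefore has no exact number, only a limit of the assay. Its place is shared with the other two compounds, as shown by the limit of > 20000 nM in this assay, at which 3 of the 3 values shown sit, and so no order among the three can be read.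

Compound 4 (`CCCCc1cc2c(=O)c(Br)c[nH]c2cc1OCCOc1ccccc1`) changes one place in compound 3: bromo in place of isopropylcarbamoyl on an aromatic carbon and the change is, in words, bromo in place of isopropylcarbamoyl on an aromatic carbon.

The nearest measured changes are a step that the two limits leave unreadable from compound 1 to compound 2 and a step that the two limits leave unreadable from compound 1 to compound 3 and a step that the two limits leave unreadable from compound 2 to compound 3 and each alters only part of that same group. None removes the whole group, so they are a weak guide. The expected change in this assay is a number no higher from compound 3 to compound 4 (the limit leaves the size open) and it is estimated to stay within the usual scatter, with no direction favoured.

Compound 4 is expected at 20000 nM with an estimated range from 8000 nM to 40000 nM and the assay will most likely report only a limit again.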

Compound 4, half-maximal effective concentration: 8070 nM
The estimate for compound 4 lay 2.5-fold (0.39 log units) above the measured number; the measured number falls inside the stated range.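

In this assay, bromo on this aromatic carbon gives the only exact number among the compounds shown, and the change brings an at least 2.4-fold lower number from compound 3 to compound 4 (0.39 log units; beyond the scatter), an at least 2.4-fold lower number from compound 2 to compound 4 (0.39 log units; beyond the scatter) and an at least 2.4-fold lower number from compound 1 to compound 4 (0.39 log units; beyond the scatter). The group at this position therefore does matter in this assay: ethoxycarbonyl, carboxy and isopropylcarbamoyl all leave the compound at the limit, whereas bromo gives a number that can be read. On these data alone, the true size of each step stays open, and the steps among the three earlier compounds cannot be read, as all three sit at the same limit: the limit of > 20000 nM in this assay, at which 3 of the 4 values shown sit.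

As far as these compounds go, whether the lower number belongs to bromo itself or to the loss of a carbonyl-bearing group remains open. Chloro, a nitrile or plain hydrogen on this carbon could help separate those two readings.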